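This account rests on a few compounds, and the source may have more. Where it says the series, first, only, none or still open, it means among the compounds named here.

Series notes. Among the measured compounds shown here, compound 1, `COc1cccc(Sc2c(NS(=O)(=O)c3ccc(C(C)(C)C)cc3)noc2C)c1`, is the only member with a number in an assay on A7R5 cells for displacement of a labelled ligand from Endothelin-1 receptor (Rattus norvegicus); a higher number here means a weaker inhibitor, a lower number a stronger inhibitor; compound 1 gives 530 nM. Compound 2, `Cc1onc(NS(=O)(=O)c2ccc(C(C)(C)C)cc2)c1I`, in this assay reaches only > 100000 nM, which is a limit of the measurement and not a number. For the measured compounds named here, the one measured step, an at least 180-fold higher number from compound 1 to compound 2 (2.27 log units; beyond the scatter), rests on the limit of > 100000 nM in this assay, at which 1 of the 2 values shown sits, and concerns the (3-methoxyphenyl)sulfanyl group on the aromatic carbon, a part of the core that compound 3 keeps.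

Compound 3, `COc1cccc(Sc2c(NS(=O)(=O)c3ccc(C(C)(C)C)cc3)noc2CCCC(N)=O)c1`, differs from compound 1 elsewhere: 2-carbamoylethyl in place of hydrogen on a saturated chain carbon bound to an aromatic carbon, so that the methyl on the core becomes a 3-carbamoylpropyl chain. Going by the values given here, no measured step touches this position, so the measured evidence gives no direction for it; the expectation is a step of a 1.1-fold lower number from compound 1 to compound 3 (0.03 log units; within the scatter), within the scatter. Compound 3 is therefore estimated at 500 nM, expected between 150 nM and 1700 nM in this assay.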

Compound 3, half-maximal inhibitory concentration: 6300 nM
Beside the measured number, compound 3's estimate is 13-fold (1.10 log units) below it; measured number above the stated range.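

In this assay the methyl on the core is not a free position: going to 3-carbamoylpropyl gives a 12-fold higher number from compound 1 to compound 3 (1.08 log units; beyond the scatter) and so the first measured direction for this place, toward weaker inhibition. This saturated chain carbon bound to an aromatic carbon thus joins the place of the (3-methoxyphenyl)sulfanyl group as a site where a single change moves the number beyond the scatter. Nothing measured here bears on why the longer amide-ended chain weakens inhibition.

As far as these compounds go, whether the step belongs to chain length or to the terminal amide stays open: a plain propyl or butyl chain, or the same chain ending in a carboxylic acid or an amine, would separate the two. An ethyl group would show whether a smaller extension of the methyl already raises the number in this assay.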